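The compounds below may be only part of what the source reports. "The series", "measured", "known", "first", "only" and "open" are said of these compounds alone.

Working notes on the series. Three compounds share one core: compound 1 `Cc1nc(-c2ccc(Cl)cc2)sc1C(=O)CSc1nc(-c2ccccc2)c(C#N)c(=O)[nH]1`, compound 2 `COc1ccc(-c2nc(SCC(=O)c3sc(-c4ccc(Cl)cc4)nc3C)[nH]c(=O)c2C#N)cc1` and compound 3 `COc1ccc(-c2nc(SCC(=O)c3sc(-c4ccc(Cl)cc4)nc3C)[nH]c(=O)c2C#N)cc1OC`. In a functional assay on U-87MG ATCC cells for antiproliferative activity against U-87 MG (Homo sapiens), read by MTT assay, with a stated time of 48 h, tested at 5 uM (on this read-out lower numbers stand for a stronger effect and higher numbers for a weaker effect at the one concentration tested), compound 1 gives 88.9%, compound 2 gives 92.1% and compound 3 gives 93.4%. Compound 3 holds the highest of the three numbers, but the gap to its nearest neighbour, a number 1.3 percentage points higher from compound 2 to compound 3 (within the scatter), and the gap to the furthest, a number 4.5 percentage points higher from compound 1 to compound 3 (within the scatter), both sit within the scatter, so the three compounds cannot be ordered on these data. The two single changes of methoxy for hydrogen, a number 3.2 percentage points higher from compound 1 to compound 2 (within the scatter) and a number 1.3 percentage points higher from compound 2 to compound 3 (within the scatter), likewise moved nothing beyond the scatter.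

Compound 4 `COc1cccc(-c2nc(SCC(=O)c3sc(-c4ccc(Cl)cc4)nc3C)[nH]c(=O)c2C#N)c1` is the next member. Against compound 3 the difference is hydrogen in place of methoxy on an aromatic carbon. This is the reverse of the kind of change seen in the measured steps, placed on the aromatic carbon ortho to a methoxy group and para to a large group; a 3-methoxyphenyl member has not itself been measured. Since neither addition of methoxy shifted the read-out, its removal is expected to shift it no further: the step is estimated as a number 2.4 percentage points lower from compound 3 to compound 4 (within the scatter). Compound 4 is therefore expected to give about 91%, with a range from 84% to 98%.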

Compound 4, a percentage reported as activity, at one concentration (the size of the read-out at that concentration, not a potency): 96.6%
Beside the measured number, compound 4's estimate is 5.6 percentage points below it; low and high end bracket the measured number.
By their numbers in this assay, from the lowest: compounds 1, 2, 3 and 4 (each within the scatter of the next).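

Going from 3,4-dimethoxyphenyl to 3-methoxyphenyl in this assay gives a number 3.2 percentage points higher from compound 3 to compound 4 (within the scatter), so losing the methoxy on this aromatic carbon, ortho to a methoxy group and para to a large group, leaves the read-out within the scatter, and the same change agrees across the two cores on which it can be read: the same change on two cores in this assay, a number 3.2 percentage points higher (within the scatter) from compound 1 to compound 2 and a number 3.2 percentage points lower (within the scatter) from compound 4 to compound 3, 6.4 percentage points apart, within the scatter of two such steps.
Shifting the single methoxy, 3-methoxyphenyl in place of 4-methoxyphenyl, gives a number 4.5 percentage points higher from compound 2 to compound 4 (within the scatter), so the read-out does not separate these two placings of the group.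
Methoxy in place of hydrogen on the phenyl of compound 1 to give the 3-methoxyphenyl member gives a number 7.7 percentage points higher from compound 1 to compound 4 (within the scatter), the widest step in the series so far yet still within the scatter, and it also agrees with the other reading of this change: the same change on two cores in this assay, a number 1.3 percentage points higher (within the scatter) from compound 2 to compound 3 and a number 7.7 percentage points higher (within the scatter) from compound 1 to compound 4, 6.4 percentage points apart, within the scatter of two such steps.

From the compounds shown here alone, all four compounds carry only hydrogen or methoxy on this phenyl ring, so whether an amine, a carboxylic acid or a longer alkoxy chain there would move the read-out beyond the scatter stays open. For the compounds shown here, since only this aryl group varies, and at a single concentration, what changes elsewhere on the shared core would do also stays open.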